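The source may hold more compounds than are shown below. What is called first, only, known or untested is meant among the compounds shown, and "the series" means these compounds.

Measured so far in an assay on membranes from uterus for displacement of a labelled ligand from Angiotensin type II receptor (Sus scrofa), with a stated time of 1.5 h; a higher number here means a weaker inhibitor, a lower number a stronger inhibitor:
compound 1, `CCCCOC(=O)NS(=O)(=O)c1sc(CC(C)C)cc1-c1ccc(C(=O)c2ncco2)cc1`, gives 13.8 nM.
compound 2, `CCCCOC(=O)NS(=O)(=O)c1sc(CC(C)C)cc1-c1ccc(CN2CCCC2=O)cc1`, gives 3.5 nM.
compound 3, `CCCCOC(=O)NS(=O)(=O)c1sc(CC(C)C)cc1-c1ccc(CN2C(=O)N(C)C(C)(C)C2=O)cc1`, gives 3.6 nM.

Compound 3 stands second highest of the three numbers in this assay. Its nearest neighbour is compound 2 (a 1.0-fold higher number from compound 2 to compound 3 (0.01 log units; within the scatter)), its furthest is compound 1 (a 3.8-fold lower number from compound 1 to compound 3 (0.58 log units; beyond the scatter)).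

Compound 4 is `CCCCOC(=O)NS(=O)(=O)c1sc(CC(C)C)cc1-c1ccc(CN2C(=O)CCC2=O)cc1`. The change from compound 3 is 2,5-dioxopyrrolidin-1-yl in place of 3,4,4-trimethyl-2,5-dioxoimidazolidin-1-yl on a saturated chain carbon bound to an aromatic carbon.

The step that bears on this most directly is a 1.0-fold higher number from compound 2 to compound 3 (0.01 log units; within the scatter), which exchanged one five-membered non-aromatic ring for another on the same saturated chain carbon bound to an aromatic carbon without any shift in this assay. The steps of a 3.9-fold lower number from compound 1 to compound 2 (0.60 log units; beyond the scatter) and a 3.8-fold lower number from compound 1 to compound 3 (0.58 log units; beyond the scatter) were modest, but each replaced the whole group on the aromatic carbon, so they speak less to a ring-only exchange. No step beyond the scatter is therefore expected for a 1.1-fold higher number from compound 3 to compound 4 (0.05 log units; within the scatter). Compound 4 is estimated at 4 nM, with a range from 1.5 nM to 11 nM.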

Compound 4, inhibition constant: > 10000 nM
Compound 4 was reported as a limit; the forecaster's own chance of this, stated with the estimate: 2%; at least 2500-fold (3.39 log units) between middle value and limit.
By their numbers in this assay, from the lowest: compounds 2 and 3 (each within the scatter of the next); then compound 1. At a limit, above all of these: compound 4.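

Exchanging 2-oxopyrrolidin-1-yl for 2,5-dioxopyrrolidin-1-yl gives an at least 2800-fold higher number from compound 2 to compound 4 (3.45 log units; beyond the scatter) and exchanging 3,4,4-trimethyl-2,5-dioxoimidazolidin-1-yl for the same ring gives an at least 2700-fold higher number from compound 3 to compound 4 (3.44 log units; beyond the scatter) even though those two earlier rings sit within the scatter of each other, so the ring on this saturated chain carbon is not freely exchangeable. Compound 3 also carries the 2,5-dioxo pattern in its ring, so the loss does not follow the two carbonyls alone, and the same ring also falls behind the (1,3-oxazol-2-yl)carbonyl group of compound 1 with an at least 720-fold higher number from compound 1 to compound 4 (2.86 log units; beyond the scatter) as the step. In this assay compound 4 is a limit and not a number: the limit of > 10000 nM in this assay, at which 1 of the 4 values shown sits.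

Still open, from the compounds shown here alone, is whether the loss follows the missing methyl groups or the missing ring nitrogen of the 3,4,4-trimethyl-2,5-dioxoimidazolidin-1-yl group. A 3,3-dimethyl-2,5-dioxopyrrolidin-1-yl group and an unsubstituted 2,5-dioxoimidazolidin-1-yl group at this place would separate the two.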